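A Neopentyl Group in Place of Cyclopropylmethyl: Expected Solubility

A few compounds are considered here, and "the series" means these few. Any claim that something is new, unique, unknown or untested is made for them only; others in the source may bear on it.

Of the compounds shown here, three sharing one core have been measured in a physicochemical assay for solubility, measured as kinetic solubility; a lower number here means a less soluble compound, a higher number a more soluble compound. Compound 1 `CC(=O)Nc1cc(-c2ccc(N(C)C(=O)c3c(F)cccc3Cl)c(N3CC4CC4C3)c2)n(C2CCC2)n1` gives 0.5 ug/mL, and compound 2 `CC(=O)Nc1cc(-c2ccc(N(C)C(=O)c3c(F)cccc3Cl)c(N3CC4CC4C3)c2)n(C(C)C2CC2)n1` gives 0.5 ug/mL. Compound 3 `CC(=O)Nc1cc(-c2ccc(N(C)C(=O)c3c(F)cccc3Cl)c(N3CC4CC4C3)c2)n(CC2CC2)n1` gives 10.1 ug/mL, the highest of the three numbers, standing a 20-fold higher number from compound 1 to compound 3 (1.31 log units; beyond the scatter) and a 20-fold higher number from compound 2 to compound 3 (1.31 log units; beyond the scatter). The step of no change at the digits printed from compound 1 to compound 2 (within the scatter) shows that the two lower values do not differ beyond the scatter.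

Compound 4 `CC(=O)Nc1cc(-c2ccc(N(C)C(=O)c3c(F)cccc3Cl)c(N3CC4CC4C3)c2)n(CC(C)(C)C)n1` has not yet been measured. It differs from compound 3 by tert-butyl in place of cyclopropyl on a saturated chain carbon bound to an aromatic nitrogen, so that the cyclopropylmethyl group of compound 3 becomes neopentyl. Within the data shown here, two measured steps bear on this: a 20-fold higher number from compound 2 to compound 3 (1.31 log units; beyond the scatter), and a 20-fold higher number from compound 1 to compound 3 (1.31 log units; beyond the scatter). In both, the cyclopropylmethyl compound 3 holds the higher number while the cyclobutyl of compound 1 and the 1-cyclopropylethyl of compound 2 hold the lower. A large downward step is therefore expected for compound 4, a 10-fold lower number from compound 3 to compound 4 (1.00 log units; beyond the scatter), because of a 20-fold higher number from compound 2 to compound 3 (1.31 log units; beyond the scatter). Compound 4 is estimated at 1 ug/mL, with a range from 0.3 ug/mL to 5 ug/mL.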

Compound 4, solubility: 0.8 ug/mL
Estimate against measurement, compound 4: 1.3-fold (0.10 log units) above, and the stated range covers the measured number.
By their numbers in this assay, from the lowest: compounds 1, 2 and 4 (each within the scatter of the next); then compound 3.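

The step of a 13-fold lower number from compound 3 to compound 4 (1.10 log units; beyond the scatter) in this assay shows that the high number of compound 3 does not survive a change made only at the far end of the group, with the saturated chain carbon bound to the aromatic nitrogen left unbranched. With a 1.6-fold higher number from compound 2 to compound 4 (0.20 log units; within the scatter) and a 1.6-fold higher number from compound 1 to compound 4 (0.20 log units; within the scatter) both printed, the neopentyl compound cannot be told apart from the two lower compounds, so compound 3 alone stands apart among the four. No measurement shown here accounts for this difference.

As far as these compounds go, whether cyclopropyl is unusual on this chain carbon, or whether other groups there would do as well, remains open. An oxetane, a cyclobutyl or a dimethylamine in its place could each be compared with compound 3 at 10.1 ug/mL in this assay for an answer.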